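The compounds below may be only part of what the source reports. "The series", "measured", "known", "first", "only" and "open" are said of these compounds alone.

Measured so far:
- Compound 1 `COc1ccc([C@H]2CC(C)(O)[C@@H]3CC[C@@H](C)C[C@H]3O2)cc1OC`: in an ADME assay on MDCK cells (Canis lupus familiaris) for cytotoxicity, read by MTT assay, with a stated time of 48 h (a lower number here means that less compound is tolerated, a higher number that more compound is tolerated), compound 1 gives > 937000 nM, which is a limit of the assay and not a number.
- Compound 2 `COc1cc([C@H]2CC(C)(O)[C@@H]3CC[C@@H](C)C[C@H]3O2)cc(OC)c1OC`: in this assay compound 2 gives 405000 nM.
- Compound 3 `COc1ccc([C@H]2CC(C)(F)[C@@H]3CC[C@@H](C)C[C@H]3O2)c(OC)c1`: in this assay compound 3 gives 379000 nM.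

Compound 2 differs from compound 1 by methoxy in place of hydrogen on an aromatic carbon; that step gave an at least 2.3-fold lower number from compound 1 to compound 2 (0.36 log units; beyond the scatter), noting (the limit of > 937000 nM in this assay, at which 1 of the 3 values shown sits). The difference between the core of compound 3 and the core of compound 1 is not broken down here. Compound 4 `COc1cc(OC)c([C@H]2CC(C)(F)[C@@H]3CC[C@@H](C)C[C@H]3O2)c(OC)c1` is not yet measured and differs from compound 3 by methoxy in place of hydrogen on an aromatic carbon. This is the same kind of change as from compound 1 to compound 2, but the surroundings differ: in compound 2 the entering methoxy sits ortho to a methoxy group, meta to a large group and meta to a methoxy group, whereas in compound 4 it sits ortho to a large group and meta to two methoxy groups. For compound 4 in this assay a step of a 1.9-fold lower number from compound 3 to compound 4 (0.28 log units; within the scatter) is expected, resting on the lowering that compound 2 showed in an at least 2.3-fold lower number from compound 1 to compound 2 (0.36 log units; beyond the scatter). Compound 4 is estimated at 200000 nM, expected between 90000 nM and 450000 nM.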

Compound 4, half-maximal cytotoxic concentration: 851000 nM
Compound 4: the middle estimate sits 4.3-fold (0.63 log units) below what was measured; measured number above the stated range.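

In this assay, methoxy in place of hydrogen on an aromatic carbon gives a 2.2-fold higher number from compound 3 to compound 4 (0.35 log units; beyond the scatter), so the direction of the step does not carry from one core to the other: the same change on two cores in this assay, an at least 2.3-fold lower number (0.36 log units; beyond the scatter) from compound 1 to compound 2 and a 2.2-fold higher number (0.35 log units; beyond the scatter) from compound 3 to compound 4, at least 5.1-fold (0.71 log units) apart, beyond the scatter of two such steps. The earlier step rests on a limit of the assay and not a number: the limit of > 937000 nM in this assay, at which 1 of the 4 values shown sits. The two steps differ both in the core and in where the methoxy enters, ortho to a large group in compound 4, and these pairs cannot separate those two differences.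

Still open, going by these compounds, is what methoxy does on each core when it enters at the place it takes on the other. Also open, on these data alone, is whether an amine or a carboxylic acid at the place of that methoxy would follow either step.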